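Swapping ethyl for hydroxy on a shared core

The source may hold more compounds than are shown below. What is called first, only, known or untested is meant among the compounds shown, and "the series" means these compounds.

Measured so far:
- compound 1, `O=C1/C(=C/c2ccc(O)cc2)Oc2cccc(O)c21`: 71%
- compound 2, `O=C1/C(=C/c2ccc(O)cc2)Oc2cc(O)ccc21`: 69%
- compound 3, `CCc1ccccc1/C=C1\Oc2cc(O)cc(O)c2C1=O`: 0%

All three compounds share a core and were tested in an assay on cells for inhibition of Tyrosinase (Homo sapiens), tested at 0.1 mM; on this read-out lower numbers stand for less inhibition and higher numbers for more inhibition at the one concentration tested (going by the name of the read-out). Compound 1 gives 71% and compound 2 gives 69%; these two numbers lie within the usual scatter of each other, so no order between them can be read. Compound 3 stands lowest of the three, with 0%; its gap to compound 2 and its gap to compound 1 are both beyond the scatter.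

Compound 4, `O=C1/C(=C/c2ccccc2O)Oc2cc(O)cc(O)c21`, has not yet been measured. It differs from compound 3 in one place: hydroxy in place of ethyl on an aromatic carbon. Among the compounds with values here, no step between measured compounds covers this exact change, so the expectation must lean on what the numbers show. Compounds 1 and 2, each carrying a hydroxy on the pendant ring, sit well above compound 3, whose pendant ring carries an ethyl instead.

For compound 4, a rise from the number of compound 3 is expected, because compound 3 gives 0% while compound 1 gives 71%; the step from compound 3 to compound 4 is estimated at a number 35 percentage points higher from compound 3 to compound 4 (beyond the scatter). The estimate for compound 4 in this assay is 35%, with a range from 5% to 70%.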

Compound 4, a percentage reported as inhibition, at one concentration (the size of the read-out at that concentration, not a potency): 4%
Beside the measured number, compound 4's estimate is 31 percentage points above it, and the stated range ends above it.
By their numbers in this assay, from the lowest: compounds 3 and 4 (each within the scatter of the next); then compounds 2 and 1 (each within the scatter of the next).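

In this assay, putting hydroxy in place of ethyl on an aromatic carbon, ortho to a large group, gives a number 4 percentage points higher from compound 3 to compound 4 (within the scatter), so on this core the swap makes no difference that can be read. Within the data shown here, this is the first pair that isolates the swap: compounds 1 and 2 differ from compound 3 in more than one place, so they could not show what a hydroxy does at this position alone, and here it does not lift the number out of the scatter. No measurement at hand explains why this position behaves this way.

The compounds shown leave open whether an amine, a methoxy group or a carboxylic acid on this same aromatic carbon would move the number beyond the scatter. As far as these compounds go, it also remains open whether the swap of ethyl for hydroxy would read the same on the core of compound 1 or compound 2, where the other hydroxy groups sit differently and the numbers stand far from the bottom of the scale.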